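Ester aryl swap on a triterpenoid series

The compounds below may be only part of what the source reports. "The series", "measured", "known", "first", "only" and "open" are said of these compounds alone.

Measured so far:
- compound 1 `CC1=CC[C@H]2[C@H](CC[C@]2(C)O)C(C)(C)[C@@H]1CC[C@H]1[C@]2(C)CC[C@H](OC(=O)c3ccncc3)C(C)(C)O[C@H]2CC[C@@]1(C)O`: 25300 nM
- compound 2 `CC1=CC[C@H]2[C@H](CC[C@]2(C)O)C(C)(C)[C@@H]1CC[C@H]1[C@]2(C)CC/C(=N/O)C(C)(C)O[C@H]2CC[C@@]1(C)O`: 46800 nM
- compound 3 `CC1=CC[C@H]2[C@H](CC[C@]2(C)O)C(C)(C)[C@@H]1CC[C@H]1[C@]2(C)CC/C(=N/OC(=O)c3ccccc3)C(C)(C)O[C@H]2CC[C@@]1(C)O`: 25600 nM

All three were run in a functional assay on MCF7 cells (Homo sapiens) for antiproliferative activity, read by MTT assay, with a stated time of 72 h; a lower number here means a stronger inhibitor, a higher number a weaker inhibitor. Compound 1 gives the lowest of the three numbers, with 25300 nM, but its nearest neighbour, compound 3, gives 25600 nM, and compound 2 gives 46800 nM; both gaps to compound 1 fall within the scatter, so no ordering among the three can be claimed.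

Going by the values given here, the one counted step so far, a 1.8-fold lower number from compound 2 to compound 3 (0.26 log units; within the scatter), concerns the oxime oxygen and does not touch the ester aryl group.

Compound 4 `CC1=CC[C@H]2[C@H](CC[C@]2(C)O)C(C)(C)[C@@H]1CC[C@H]1[C@]2(C)CC[C@H](OC(=O)c3ccccc3F)C(C)(C)O[C@H]2CC[C@@]1(C)O` differs from compound 1 only at the ester: 2-fluorophenyl in place of pyridin-4-yl on a carbonyl carbon. Among the compounds with values here, no measured pair bears on this change, and the single step that exists was itself within the scatter. For compound 4 the expected result is therefore no step beyond the scatter, a 1.0-fold lower number from compound 1 to compound 4 (0.01 log units; within the scatter). The estimate for compound 4 in this assay is 25000 nM, with a range of 8000 nM to 80000 nM.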

Compound 4, half-maximal inhibitory concentration: 11300 nM
Compound 4: middle estimate off by 2.2-fold (0.34 log units), on the high side; measured number inside the range.
By their numbers in this assay, from the lowest: compound 4; then compounds 1, 3 and 2 (each within the scatter of the next).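

Going by these compounds alone, the ester aryl group on a carbonyl carbon is the first place where a single change gives a step beyond the scatter: in this assay, 2-fluorophenyl in place of pyridin-4-yl gives a 2.2-fold lower number from compound 1 to compound 4 (0.35 log units; beyond the scatter) and the step is modest. The earlier counted step concerned the oxime oxygen and stayed within the scatter, so this position is the only one shown so far to alter the number in this assay. No measurement shown accounts for the step.

Since the change removes the pyridine ring and brings in a fluorine-bearing ring at once, the compounds shown cannot separate the two. As far as these compounds go, whether plain phenyl on the same carbonyl carbon gives the lower number, or whether an amine on that ring changes it, remains open.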